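Thiophen-2-yl in place of 3-methoxyphenyl

The source may hold more compounds than are shown below. What is called first, only, known or untested is meant among the compounds shown, and "the series" means these compounds.

In a physicochemical assay for solubility, in phosphate buffer, at pH 7.4 (a lower number here means a less soluble compound, a higher number a more soluble compound), compound 1 `CCOC(=O)c1c(-c2cccc(C)c2)[nH]c2cc(OC)ccc2c1=O` gives 48000 nM. Compound 2 `CCOC(=O)c1c(-c2cccc(OC)c2)[nH]c2cc(OC)ccc2c1=O` reads > 100000 nM, which is a limit and not a number, and so it stands at the limit of > 100000 nM in this assay, at which 1 of the 2 values shown sits. Within the data shown here, the only measured step is an at least 2.0-fold higher number from compound 1 to compound 2 (0.31 log units; beyond the scatter), with methoxy in place of methyl on an aromatic carbon. Compound 3 `CCOC(=O)c1c(-c2cccs2)[nH]c2cc(OC)ccc2c1=O` has not yet been measured. It differs from compound 2 by thiophen-2-yl in place of 3-methoxyphenyl on an aromatic carbon, with thiophen-2-yl in place of 3-methoxyphenyl on an aromatic carbon. The methoxy of the measured step leaves with that ring, so this step bears only loosely on the change, and the expectation leans on compound 1 at 48000 nM. A modest fall is expected, an estimated at least 1.8-fold lower number from compound 2 to compound 3 (0.25 log units; that floor lies within the scatter). For compound 3 the estimate is 55000 nM, with an expected range of 20000 nM to 100000 nM.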

Compound 3, solubility: > 100000 nM
Compound 3 gave a limit, no number; the forecaster's own chance of this, stated with the estimate: 30%; middle value at least 1.8-fold (0.25 log units) away from the limit.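

In this assay, thiophen-2-yl in place of 3-methylphenyl on the aromatic carbon next to the ring nitrogen gives an at least 2.0-fold higher number from compound 1 to compound 3 (0.31 log units; beyond the scatter). A methoxy group is therefore not required for a step of this kind at this position, since a five-membered aromatic ring with no methoxy group also gives one. The step between the two rings themselves cannot be read, because both compounds stand at a limit of the assay and not at a number: the limit of > 100000 nM in this assay, at which 2 of the 3 values shown sit.

Going by these compounds, how far compound 2 and compound 3 lie past that limit remains open, and so does any order between 3-methoxyphenyl and thiophen-2-yl. Also open, on these data alone, is how an amine or a carboxylic acid on the thiophen-2-yl ring would read in this assay.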